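This account rests on a few compounds, and the source may have more. Where it says the series, first, only, none or still open, it means among the compounds named here.

Measured compounds in an assay on Sf9 cells for inhibition of serine/threonine-protein kinase 4 (Homo sapiens), read by luminescence and ADP-Glo, with a stated time of 1 h, in the presence of a further agent that is not named here; a higher number here means a weaker inhibitor, a lower number a stronger inhibitor:
compound 1, `CCC1C(=O)N(C)c2cnc(Nc3ccc(S(N)(=O)=O)cc3)nc2N1C`, 479 nM;
compound 2, `CC(C)C1C(=O)N(C)c2cnc(Nc3ccc(S(N)(=O)=O)cc3)nc2N1C`, 254 nM;
compound 3, `CNS(=O)(=O)c1ccc(Nc2ncc3c(n2)N(C)C(c2ccccc2C)C(=O)N3C)cc1`, 104 nM.

Compound 2 differs from compound 1 by methyl in place of hydrogen on a saturated chain carbon bound to a saturated chain carbon and a saturated ring carbon, and in this assay this gave a 1.9-fold lower number from compound 1 to compound 2 (0.28 log units; within the scatter). Compound 3 stands lowest of the three, and the difference between its core and that of compound 1 is not broken down here.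

Compound 4, `CCNS(=O)(=O)c1ccc(Nc2ncc3c(n2)N(C)C(c2ccccc2C)C(=O)N3C)cc1`, is not yet measured. It differs from compound 3 by methyl in place of hydrogen on a saturated chain carbon bound to a sulfonamide nitrogen. This is the same kind of change as from compound 1 to compound 2, but the place differs: there the carbon was bound to a saturated chain carbon and a saturated ring carbon, here it is bound to a sulfonamide nitrogen. Going by the values given here, the one measured step of this kind stayed within the scatter, so from compound 3 to compound 4 a step of about a 1.0-fold lower number from compound 3 to compound 4 (0.02 log units; within the scatter) is expected. For compound 4 in this assay the estimate is 100 nM, between 40 nM and 250 nM.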

Compound 4, half-maximal inhibitory concentration: 119 nM
Estimate against measurement, compound 4: 1.2-fold (0.08 log units) below; the measured number falls inside the stated range.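

In this assay, methyl in place of hydrogen on a saturated chain carbon bound to a sulfonamide nitrogen gave a 1.1-fold higher number from compound 3 to compound 4 (0.06 log units; within the scatter). Set beside the earlier step, the same change shows no readable difference between the two cores: the same change on two cores in this assay, a 1.9-fold lower number (0.28 log units; within the scatter) from compound 1 to compound 2 and a 1.1-fold higher number (0.06 log units; within the scatter) from compound 3 to compound 4, 2.2-fold (0.33 log units) apart, within the scatter of two such steps. Going by these compounds alone, this shows only that neither step moved the number beyond the scatter; the change sits at a different place in each case, and two small steps do not establish how it would carry to other cores or places.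

Open, on these data alone, is whether a longer chain, such as propyl or butyl, in place of the ethyl of compound 4 would leave the number within the scatter. Also open, as far as these compounds go, is whether an amine or a carboxylic acid there would do the same.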